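The compounds below may be only part of what the source reports. "The series", "measured", "known", "first", "only" and "open" are said of these compounds alone.

Measured so far in a functional assay on HepG2 cells (Homo sapiens) for cytotoxicity, read by MTT assay, with a stated time of 48 h; a higher number here means a weaker inhibitor, a lower number a stronger inhibitor:
compound 1 `COc1cc(/C=C/C(=O)/C=C/c2nc3ccccc3n2C)ccc1O`: 2900 nM
compound 2 `COc1cc(/C=C/C(=O)/C=C/c2nc3c(C)cccc3n2C)ccc1O`: 1900 nM
compound 3 `COc1cc(/C=C/C(=O)/C=C/c2nc3c(C)c(C)ccc3n2C)ccc1O`: 8500 nM

Compound 1 stands second highest of these three numbers. Its nearest neighbour is compound 2, with a 1.5-fold lower number from compound 1 to compound 2 (0.18 log units; within the scatter); compound 3 is furthest, its number higher than that of compound 1 by more than the scatter.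

Compound 4 `COc1cc(/C=C/C(=O)/C=C/c2nc3cc(Cl)ccc3n2C)ccc1O` differs from compound 1 by chloro in place of hydrogen on an aromatic carbon. Both measured steps also alter an aromatic carbon of the shared core, but each adds a methyl: a 1.5-fold lower number from compound 1 to compound 2 (0.18 log units; within the scatter) and a 4.5-fold higher number from compound 2 to compound 3 (0.65 log units; beyond the scatter). Going by the values given here, no measured step exchanges hydrogen for chloro, so these bear only loosely on compound 4. The expectation is therefore no step beyond the scatter in this assay, no change at the digits printed from compound 1 to compound 4 (within the scatter). Compound 4 is estimated at 2900 nM, within 1200 nM to 7000 nM.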

Compound 4, half-maximal inhibitory concentration: 4000 nM
Compound 4: middle estimate off by 1.4-fold (0.14 log units), on the low side; the range from low to high includes it.
By their numbers in this assay, from the lowest: compounds 2, 1 and 4 (each within the scatter of the next, the first and the last beyond it); then compound 3.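

In this assay, going by these compounds alone, chloro on this aromatic carbon gives a 1.4-fold higher number from compound 1 to compound 4 (0.14 log units; within the scatter) and so stays within the scatter, which the earlier compounds could not show, as their measured steps only exchange hydrogen for methyl. At this position of the shared core, then, the one chloro shown leaves the number indistinguishable from that of compound 1. Nothing measured here explains this result.

Going by these compounds, whether an amine or a carboxylic acid on this same carbon would also stay within the scatter remains open. So does whether chloro on the other carbons of this ring would do so.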